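Replacing pyridin-3-yl with methoxy in the series

The source may report more compounds than this note shows. Statements on the series, on what has been measured and on what is new or still open speak of the compounds shown alone.

Measured so far in a functional assay on KG-1 cells (Homo sapiens) for cytotoxicity, read by luminescence and CellTiter-Glo, with a stated time of 3 days (a higher number here means a weaker inhibitor, a lower number a stronger inhibitor), for three compounds:
compound 1 `N#Cc1ccc(NC(=O)c2ccc(Cl)cc2O)cc1` gives 1920 nM
compound 2 `O=C(Nc1cc(Cl)cc(Cl)c1)c1cc(F)ccc1O` gives 780 nM
compound 3 `N#Cc1ccc(NC(=O)c2ccc(-c3cccnc3)cc2O)cc1` gives 7940 nM

Compound 3 at 7940 nM has the highest of the three numbers, and its gaps to compound 1 and compound 2 both lie beyond the scatter. The next structure is compound 4 `COc1ccc(C(=O)Nc2ccc(C#N)cc2)c(O)c1` with methoxy in place of pyridin-3-yl on an aromatic carbon at the position para to a large group. Among the measured compounds shown here, one measured step bears on this place: a 4.1-fold higher number from compound 1 to compound 3 (0.62 log units; beyond the scatter) with pyridin-3-yl in place of chloro. Compound 2 differs from the others in more than one place and gives no direct guide. For the measured compounds named here, no methoxy compound has been measured, so compound 1 at 1920 nM serves only as a rough reference for a small group here. A lower number is therefore expected, with a step somewhat smaller than the measured one: a 2.6-fold lower number from compound 3 to compound 4 (0.42 log units; beyond the scatter) is the expected change in this assay for now. For compound 4 the estimate is 3000 nM with an expected range from 1000 nM to 9000 nM in this assay when tested.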

Compound 4, half-maximal inhibitory concentration: 5430 nM
Compound 4: the middle estimate sits 1.8-fold (0.26 log units) below what was measured, and the stated range covers the measured number.
By their numbers in this assay, from the lowest: compound 2; then compound 1; then compounds 4 and 3 (each within the scatter of the next).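

In this assay, methoxy in place of pyridin-3-yl at this place, para to a large group, gives a step within the scatter (a 1.5-fold lower number from compound 3 to compound 4 (0.17 log units; within the scatter)), so these two groups are not told apart here despite the loss of the six-membered aromatic ring. Chloro does stand apart from methoxy (a 2.8-fold higher number from compound 1 to compound 4 (0.45 log units; beyond the scatter)), so among compounds 1, 3 and 4 a small group does not by itself restore the number of compound 1, and chloro gives the lowest number of the three. Nothing at hand gives a reason for these differences.

On these data alone, whether an amine, a carboxylic acid or a longer ether chain at this place would give a number below that of compound 1 stays open. Compound 2 differs in more than one place, so its number cannot be credited to any single change.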